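One Aryl Ring Changed on a Shared Core

The source may report more compounds than this note shows. Statements on the series, on what has been measured and on what is new or still open speak of the compounds shown alone.

Compound 1, `COc1cccc(/C=C/C(=O)c2sc(Nc3cccc(C)c3)nc2C)c1`: in a functional assay on NCI-H460 cells (Homo sapiens) for cytotoxicity, read by MTT assay (on this read-out higher numbers stand for weaker inhibition and lower numbers for stronger inhibition), compound 1 gives > 25000 nM, which is a limit of the assay and not a number.
Compound 2, `COc1cccc(/C=C/C(=O)c2sc(Nc3ccc(Cl)cc3)nc2C)c1`: in this assay compound 2 gives > 25000 nM, likewise a limit.
Compound 3, `COc1cccc(/C=C/C(=O)c2sc(Nc3ccccc3)nc2C)c1`: in this assay compound 3 gives > 25000 nM, also a limit.

Compound 1 therefore stands at the edge of what this assay can report, and so do its two neighbours (the limit of > 25000 nM in this assay, at which 3 of the 3 values shown sit). The three measured steps, a step that the two limits leave unreadable from compound 1 to compound 2, a step that the two limits leave unreadable from compound 1 to compound 3 and a step that the two limits leave unreadable from compound 2 to compound 3, all change the ring on the nitrogen and none of them yields a readable size or direction.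

Compound 4, `Cc1cccc(Nc2nc(C)c(C(=O)/C=C/c3ccccc3Cl)s2)c1`, changes a different part of the molecule: 2-chlorophenyl in place of 3-methoxyphenyl on a double-bonded chain carbon bound to a double-bonded chain carbon. Among the measured compounds shown here, no measured step touches that ring, so nothing measured here bears directly on this change, and the three limits give no sign that any variation reaches a measurable number. The expectation for compound 4 is therefore that this assay again reports a limit rather than a value. Compound 4 is estimated at 25000 nM, within a range from 10000 nM to 60000 nM. That estimate means a step of a number no higher from compound 1 to compound 4 (the limit leaves the size open), which is expected to be no change beyond the scatter.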

Compound 4, half-maximal inhibitory concentration: > 25000 nM
Compound 4 ended at the assay's limit (the forecaster's own chance of this, stated with the estimate: 75%); the middle value sits exactly at the limit.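

No new step can be read, since compound 1 and compound 4 each give a limit and not a number, and the whole set shares that position: the limit of > 25000 nM in this assay, at which 4 of the 4 values shown sit.

The compounds shown leave open which change to the shared core, if any, would give a measurable value in this assay.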